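The compounds below may be only part of what the source reports. "The series", "measured", "known", "first", "only" and "open" are said of these compounds alone.

Measured so far in an ADME assay on Caco-2 cells (Homo sapiens) for permeability; on this read-out higher numbers stand for higher permeability and lower numbers for lower permeability:
- compound 1 `CC(C)Oc1cc(-c2cncc(-c3cnn(C4COC4)c3)c2)ccc1C(N)=O` gives 25 10^-6 cm/s
- compound 2 `Cc1[nH]ncc1-c1cncc(-c2ccc(C(N)=O)c(OC(C)C)c2)c1` gives 33 10^-6 cm/s

Compound 2 stands within the scatter of compound 1, so no order can be read between them. Compound 3 `Cc1n[nH]c(C)c1-c1cncc(-c2ccc(C(N)=O)c(OC(C)C)c2)c1` differs from compound 2 by one change, (methyl in place of hydrogen on an aromatic carbon), which turns 5-methyl-1H-pyrazol-4-yl into 3,5-dimethyl-1H-pyrazol-4-yl. Among the measured compounds shown here, the only measured step that bears on it, a 1.3-fold higher number from compound 1 to compound 2 (0.12 log units; within the scatter), altered the same substituent and stayed small, though it is a different change. In this assay no shift beyond the scatter is therefore expected. The estimated move is a 1.1-fold lower number from compound 2 to compound 3 (0.04 log units; within the scatter). Compound 3 is expected at 30 10^-6 cm/s, with an estimated range from 15 10^-6 cm/s to 55 10^-6 cm/s.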

Compound 3, apparent permeability: 41 10^-6 cm/s
Compound 3: middle estimate off by 1.4-fold (0.14 log units), on the low side; low and high end bracket the measured number.
By their numbers in this assay, from the lowest: compounds 1, 2 and 3 (each within the scatter of the next).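

Methyl in place of hydrogen on this aromatic carbon of the five-membered ring gives a 1.2-fold higher number from compound 2 to compound 3 (0.09 log units; within the scatter) in this assay, so this position takes a methyl with no shift that can be read. Swapping the whole substituent gives a 1.6-fold higher number from compound 1 to compound 3 (0.21 log units; within the scatter), which keeps all three compounds within the scatter of one another. No measurement at hand speaks to what lies behind these small steps.

The compounds shown leave open whether an amine, a carboxylic acid or a longer chain on this carbon would move the number beyond the scatter.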